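The source may hold more compounds than are shown below. What is called first, only, known or untested is meant among the compounds shown, and "the series" means these compounds.

Measured compounds:
- compound 1, `Cc1ccc([C@@H](C)Oc2cc3onc(CCC(=O)O)c3cc2Cl)nc1`, 1.59 nM
- compound 2, `Cc1ccc([C@@H](C)Oc2cc3oc(=O)n(CCC(=O)O)c3cc2Cl)nc1`, 6.31 nM
- compound 3, `CCc1cc2oc(=O)n(CCC(=O)O)c2cc1Cl`, 316 nM

All three were tested in an assay on HEK293 cells for inhibition of kynurenine 3-monooxygenase (Homo sapiens), read by LC-MS, with a stated time of 20 h; a higher number here means a weaker inhibitor, a lower number a stronger inhibitor. Among them compound 3 gives the highest number, 316 nM, which makes it the weakest inhibitor of the three: compound 2 gives 6.31 nM, a gap that lies well outside the scatter, and compound 1 gives 1.59 nM, further still. The two stronger compounds both carry an oxygen-linked group on the aromatic carbon where compound 3 carries only an ethyl.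

Compound 4, `O=C(O)CCn1c(=O)oc2cc(OCC3CC3)c(Cl)cc21`, has not yet been measured. It differs from compound 3 in one place: cyclopropylmethoxy in place of ethyl on an aromatic carbon. Within the data shown here, no measured pair shows this exact change, so its size can only be judged from the three numbers above, where the oxygen-linked compounds 1 and 2 are the stronger ones. On that basis compound 4 is expected to give a lower number than compound 3, with a step of about an 11-fold lower number from compound 3 to compound 4 (1.02 log units; beyond the scatter), beyond the scatter. The estimate for compound 4 in this assay is 30 nM, within a range from 8 nM to 120 nM.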

Compound 4, half-maximal inhibitory concentration: 1580 nM
Estimate against measurement, compound 4: 53-fold (1.72 log units) below; measured number outside the range, above it.
By their numbers in this assay, from the lowest: compound 1; then compound 2; then compound 3; then compound 4.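

In this assay cyclopropylmethoxy in place of ethyl on this aromatic carbon gives a 5.0-fold higher number from compound 3 to compound 4 (0.70 log units; beyond the scatter) and thus a weaker inhibitor, even though the incoming group is oxygen-linked. An oxygen link at this carbon therefore does not by itself give a low number: compound 2, also oxygen-linked here, gives 6.31 nM while compound 4 gives 1580 nM and the two differ only in the group attached at this place. Nothing measured here accounts for this loss of inhibition.

Still open, going by these compounds, is what a plain methoxy group or a benzyloxy group on this carbon would give, and so whether the oxygen link, the cyclopropyl ring or the size of the group drives this step. Also open, on these data alone, is whether cyclopropylmethoxy would behave the same way on the core of compound 1.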